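Methyl for chloro on two isomeric aryl triazole cores

A few compounds are considered here, and "the series" means these few. Any claim that something is new, unique, unknown or untested is made for them only; others in the source may bear on it.

Compound 1 `Cc1cc(Cl)ccc1-c1n[nH]c(-c2ccccc2)n1` and compound 3 `Cc1ccc(Cl)cc1-c1n[nH]c(-c2ccccc2)n1` are built from the same atoms joined differently; the difference between the two cores is not broken down here. In a functional assay on the whole organism (Cricetulus griseus) with Cricetinae gen. sp. as the target (on this read-out lower numbers stand for an effect already at smaller amounts and higher numbers for an effect only at larger amounts of compound), compound 1 gives 0.14 mg/kg, while compound 3 gives 1.2 mg/kg, the highest number of the three measured compounds and beyond the scatter from both others.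

Compound 2 `Cc1ccc(-c2n[nH]c(-c3ccccc3)n2)c(C)c1` arises from compound 1 by methyl in place of chloro on an aromatic carbon. In this assay compound 2 gives 0.2 mg/kg, so the step of a 1.4-fold higher number from compound 1 to compound 2 (0.15 log units; within the scatter) is small and within the scatter.

Compound 4 `Cc1ccc(C)c(-c2n[nH]c(-c3ccccc3)n2)c1` has not been measured. It arises from compound 3 by methyl in place of chloro on an aromatic carbon. This is the same kind of change as that from compound 1 to compound 2, but not the same: in compound 2 the entering methyl sits meta to a methyl group and para to a large group, whereas in compound 4 it sits meta to a large group and para to a methyl group.

For the measured compounds named here, on the single measured instance of this kind of change, the step from compound 3 to compound 4 in this assay is expected to be small, about a 1.3-fold higher number from compound 3 to compound 4 (0.10 log units; within the scatter), resting on the step of a 1.4-fold higher number from compound 1 to compound 2 (0.15 log units; within the scatter) observed once, with added uncertainty because the surroundings of the changed carbon differ. Compound 4 is therefore estimated at 1.5 mg/kg, with a range from 0.7 mg/kg to 3.5 mg/kg.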

Compound 4, dose for half-maximal effect: > 10 mg/kg
Compound 4: only a limit was reported (the forecaster's own chance of this, stated with the estimate: 5%); at least 6.6-fold (0.82 log units) between middle value and limit.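

Methyl in place of chloro does not carry over from one core to the other in this assay: the same change on two cores in this assay, a 1.4-fold higher number (0.15 log units; within the scatter) from compound 1 to compound 2 and an at least 8.3-fold higher number (0.92 log units; beyond the scatter) from compound 3 to compound 4, at least 5.8-fold (0.76 log units) apart, beyond the scatter of two such steps

Compound 4 stands at > 10 mg/kg, which is a limit of the assay and not a number: the limit of > 10 mg/kg in this assay, at which 1 of the 4 values shown sits.

From the compounds shown here alone, the new step, an at least 8.3-fold higher number from compound 3 to compound 4 (0.92 log units; beyond the scatter), therefore has a lower bound only, and its full size stays unknown. With one pair per core, the result shows that the outcome of this change differs between these two cores, but it does not show which feature of the cores is responsible or how the change would run on any further core.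

What the compounds shown leave open is whether a fluoro, methoxy or trifluoromethyl group in place of the chloro of compound 3 would keep a measurable number in this assay. Also open, going by these compounds, is whether the gap between the two cores would persist with an amine or a carboxylic acid in place of the methyl shared by compound 1 and compound 3.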